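Fluoro to Chloro on the Aromatic Ring: An Expectation

The source may hold more compounds than are shown below. What is called first, only, known or untested is meant among the compounds shown, and "the series" means these compounds.

Compound 1 `O=C1c2ccccc2CCCN1CCN1CCC(Oc2ccccc2)CC1` in an assay on isolated protein for binding affinity to 5-hydroxytryptamine receptor 7 (Homo sapiens); a lower number here means a stronger inhibitor, a higher number a weaker inhibitor: 20.4 nM
Compound 2 `O=C1c2ccccc2CCCN1CCN1CCC(Oc2ccc(F)cc2)CC1` in this assay: 4.47 nM

Of the two measured compounds, compound 2 has the lower number in this assay; the step of a 4.6-fold lower number from compound 1 to compound 2 (0.66 log units; beyond the scatter) separates it from compound 1 by more than the usual scatter. Compound 3 `O=C1c2ccccc2CCCN1CCN1CCC(Oc2ccc(Cl)cc2)CC1` is the next member of this series and has not yet been measured. It differs from compound 2 by chloro in place of fluoro on an aromatic carbon, that is, a chloro in place of the fluoro on the aromatic carbon of the six-membered aromatic ring of carbon only, para to a large group. Within the data shown here, the only measured step that touches this position is a 4.6-fold lower number from compound 1 to compound 2 (0.66 log units; beyond the scatter), which put a fluoro where a hydrogen had been; no measured pair shows a chloro at this place, so there is no direct precedent for swapping one halogen for the other. On that basis the expected step of a 1.1-fold lower number from compound 2 to compound 3 (0.05 log units; within the scatter) is small and not beyond the scatter. Compound 3 is therefore estimated at 4 nM in this assay, with a range from 1.5 nM to 12 nM.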

Compound 3, inhibition constant: 11.8 nM
Beside the measured number, compound 3's estimate is 3.0-fold (0.47 log units) below it; the measured number falls inside the stated range.
By their numbers in this assay, from the lowest: compound 2; then compounds 3 and 1 (each within the scatter of the next).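

In this assay the two halogens are not interchangeable on this aromatic carbon, para to a large group: chloro in place of fluoro gives a 2.6-fold higher number from compound 2 to compound 3 (0.42 log units; beyond the scatter) and so takes back part of what fluoro brought with a 4.6-fold lower number from compound 1 to compound 2 (0.66 log units; beyond the scatter) in the first place. Measured against the hydrogen of the parent, chloro gives a 1.7-fold lower number from compound 1 to compound 3 (0.24 log units; within the scatter) and cannot be told apart from it, so among these three compounds only fluoro shows a step beyond the scatter from hydrogen, and a halogen at this place does not by itself lower the number. The data offer nothing that accounts for this difference between fluoro and chloro.

With only hydrogen, fluoro and chloro shown at this place, it remains open how a bromo, a methyl, a methoxy or a trifluoromethyl group would read here, and whether fluoro stands apart or merely marks one point in a wider series. As far as these compounds go, it also remains open whether the same difference between fluoro and chloro would hold on the other aromatic carbons of this ring, or with a longer chain joining the two halves of the molecule.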